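This account rests on a few compounds, and the source may have more. Where it says the series, first, only, none or still open, it means among the compounds named here.

Measured compounds:
Compound 1, `C/C(=C\c1cc(-c2ccc(F)cc2)cs1)C(N)=O`: in a functional assay on A549 cells (Homo sapiens) for cytotoxicity, read by CCK-8 assay, with a stated time of 24 h (a higher number here means a weaker inhibitor, a lower number a stronger inhibitor), compound 1 gives > 50000 nM, which is a limit of the assay and not a number.
Compound 2, `C/C(=C\c1nc(-c2ccccc2)cs1)C(N)=O`: in this assay compound 2 gives > 50000 nM, again a limit of the assay rather than a number.

Compound 2 therefore stands at the edge of what this assay can report, and it does not stand alone there: the limit of > 50000 nM in this assay, at which 2 of the 2 values shown sit. Going by the values given here, no step between two measured compounds is available, so nothing in the data shows how a change on the six-membered ring of carbon only moves the read-out.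

Compound 3, `C/C(=C\c1nc(-c2ccc(F)cc2)cs1)C(N)=O`, carries the fluoro group of compound 1 on the core of compound 2. The difference from compound 2 is fluoro in place of hydrogen on an aromatic carbon, para to a large group, with no ring added and no change in net charge.

With both measured values sitting at the limit, the expected step in this assay is none beyond the scatter, and the expected result is a step that the limit leaves unreadable from compound 2 to compound 3. Compound 3 is accordingly expected to give about 70000 nM in this assay, between 30000 nM and 300000 nM, most likely reported only as a limit.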

Compound 3, half-maximal inhibitory concentration: 13200 nM
Compound 3: the middle estimate sits 5.3-fold (0.72 log units) above what was measured; the whole stated range lies above it.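

In this assay, fluoro in place of hydrogen on an aromatic carbon of the six-membered aromatic ring of carbon only, para to a large group, yields the first reading among these compounds that is a number and not a limit, and the change gives an at least 3.7-fold lower number from compound 2 to compound 3 (0.57 log units; beyond the scatter). The true size of this step cannot be read, and it stands only as a lower bound because compound 2 sits at a limit: the limit of > 50000 nM in this assay, at which 2 of the 3 values shown sit. Compound 1 carries the same fluoro group on its own core and gives > 50000 nM, which is a limit of the assay, so the drop in the read-out is seen on the core of compound 2 but not on that of compound 1.

On these data alone, it remains open whether another group at this position, such as chloro, methoxy or an amine, would move the read-out as fluoro does, or further. The compounds shown also leave open how the read-out would respond if a carboxylic acid took the place of the amide that all three share.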